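The source may hold more compounds than are shown below. What is called first, only, known or untested is meant among the compounds shown, and "the series" means these compounds.

Values in an ADME assay on THP-1 cells (Homo sapiens) for cytotoxicity, read by resazurin assay, with a stated time of 72 h; a higher number here means that more compound is tolerated, a lower number that less compound is tolerated:
- compound 1 `CSc1ccc(C(=O)/C=C/c2ccc([N+](=O)[O-])o2)cc1`: 13100 nM
- compound 2 `CC(C)(C)c1ccc(C(=O)/C=C/c2ccc([N+](=O)[O-])s2)cc1`: 8400 nM

Compound 1 at 13100 nM stands within the scatter of compound 2 at 8400 nM, so neither separates from the other. Compound 3 `O=C(/C=C/c1ccc([N+](=O)[O-])o1)c1ccc(N2CCNCC2)cc1` carries piperazin-1-yl in place of methylsulfanyl on an aromatic carbon, para to a large group (piperazin-1-yl in place of methylsulfanyl on an aromatic carbon). Within the data shown here, no measured step bears on this change, so the expectation rests on these two values alone. In this assay the expected change is small and towards less compound tolerated, probably not beyond the scatter: a 1.5-fold lower number from compound 1 to compound 3 (0.16 log units; within the scatter). For compound 3 the estimated value is 9000 nM, with an expected range of 2500 nM to 30000 nM.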

Compound 3, half-maximal cytotoxic concentration: > 50000 nM
Compound 3 gave a limit, no number; the forecaster's own chance of this, stated with the estimate: 10%; middle value at least 5.5-fold (0.74 log units) away from the limit.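

In this assay this position on the shared core responds to substitution: piperazin-1-yl in place of methylsulfanyl on an aromatic carbon, para to a large group, gives an at least 3.8-fold higher number from compound 1 to compound 3 (0.58 log units; beyond the scatter), a step that no earlier comparison could show. Compound 3 gives > 50000 nM, which is a limit and not a number. The step therefore fixes only a lower bound on the change: the limit of > 50000 nM in this assay, at which 1 of the 3 values shown sits.

Open, on these data alone, is whether morpholin-4-yl or dimethylamino at this place moves the value in the same direction. Also open, as far as these compounds go, is whether piperazin-1-yl has the same effect on the core of compound 2.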